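From a Methyl to a 4-Phenylpiperazin-1-yl Group

This account rests on a few compounds, and the source may have more. Where it says the series, first, only, none or still open, it means among the compounds named here.

Among the measured compounds shown here, in a functional assay on the whole organism with Mus musculus as the target, in the rotarod test (a higher number here means that more compound is needed for the effect, a lower number that less compound is needed), compound 2 (`CCC(=O)NCC(=O)N(C)c1ccc(Cl)cc1C(=O)c1ccccc1Cl`) needs 36 mg/kg for the effect, the higher of the two true numbers so far. Compound 1 (`CC(C)NCC(=O)NCC(=O)N(C)c1ccc(Cl)cc1C(=O)c1ccccc1Cl`) gives the lower number, needing 13 mg/kg for the same effect. Compound 3 (`CC(C)C(=O)NCC(=O)N(C)c1ccc(Cl)cc1C(=O)c1ccccc1Cl`) has only a limit of > 100 mg/kg in this assay and not a number.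

Compound 4 (`CN(C(=O)CNC(=O)CN1CCN(c2ccccc2)CC1)c1ccc(Cl)cc1C(=O)c1ccccc1Cl`) has not been measured. It carries 4-phenylpiperazin-1-yl in place of methyl on a saturated chain carbon bound to a carbonyl carbon.

Two modest steps at this same carbon bear on the change. Methyl in place of isopropylamino gives a 2.8-fold higher number from compound 1 to compound 2 (0.44 log units; beyond the scatter) and so a nitrogen there went with a lower number. Methyl in place of hydrogen gives an at least 2.7-fold higher number from compound 2 to compound 3 (0.44 log units; beyond the scatter) and so a larger group went with a higher number. Compound 4 has both a nitrogen there and a larger group, so these two steps point in opposite directions and no step beyond the scatter is expected. The expected step is a 1.2-fold lower number from compound 2 to compound 4 (0.08 log units; within the scatter) in this assay (an uncertain estimate, as this group is far from anything measured). Compound 4 is estimated at 30 mg/kg in this assay (expected range 9 mg/kg to 100 mg/kg).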

Compound 4, dose for half-maximal effect: > 100 mg/kg
Compound 4 was reported as a limit (the forecaster's own chance of this, stated with the estimate: 25%); middle value at least 3.3-fold (0.52 log units) from the limit.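

The earlier compounds shown here linked a nitrogen at this carbon with a lower number in this assay, but this result shows that a nitrogen does not guarantee one. With 4-phenylpiperazin-1-yl in place of methyl, the result is an at least 2.7-fold higher number from compound 2 to compound 4 (0.44 log units; beyond the scatter), and with the same group in place of isopropylamino, it is an at least 7.6-fold higher number from compound 1 to compound 4 (0.88 log units; beyond the scatter). Compound 4 has a limit and not a number, as does compound 3, so the two cannot be ordered: the limit of > 100 mg/kg in this assay, at which 2 of the 4 values shown sit.

On these data alone, what a plain piperazin-1-yl or a small dimethylamino group would give at this carbon stays open, and with it how much of the change belongs to the phenyl ring. Also open, as far as these compounds go, is how far the true number of compound 4 lies beyond its limit.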